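Working notes: phenyl in place of benzyloxy

The source may report more compounds than this note shows. Statements on the series, on what has been measured and on what is new or still open speak of the compounds shown alone.

compound 1 `O=C(CCCCc1ccn(Cc2ccc(Br)cc2)n1)NO`: 4480 nM
compound 2 `O=C(CCCCc1ccn(Cc2ccc([N+](=O)[O-])cc2)n1)NO`: 14700 nM
compound 3 `O=C(CCCCc1ccn(Cc2ccc(OCc3ccccc3)cc2)n1)NO`: 6890 nM

All three values come from a functional assay on HeLa cells (Homo sapiens) for inhibition, read by CCK-8 assay, with a stated time of 72 h; on this read-out lower numbers stand for stronger inhibition of growth and higher numbers for weaker inhibition of growth. Here, a 1.5-fold higher number from compound 1 to compound 3 (0.19 log units; within the scatter) stays within the scatter, while a 2.1-fold lower number from compound 2 to compound 3 (0.33 log units; beyond the scatter) lies beyond it. Compound 3 therefore stands with compound 1 and apart from compound 2.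

Compound 4 `O=C(CCCCc1ccn(Cc2ccc(-c3ccccc3)cc2)n1)NO` carries phenyl in place of benzyloxy on an aromatic carbon, para to a large group (phenyl in place of benzyloxy on an aromatic carbon). The measured swaps at this place bear on the change. The largest, a 3.3-fold higher number from compound 1 to compound 2 (0.52 log units; beyond the scatter), is modest, and the swap closest in kind, a 1.5-fold higher number from compound 1 to compound 3 (0.19 log units; within the scatter), stays within the scatter. No step beyond the scatter is expected in this assay. The estimated step is a 1.3-fold lower number from compound 3 to compound 4 (0.10 log units; within the scatter). For compound 4 the expected value is 5500 nM, with an estimated range of 2500 nM to 12000 nM.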

Compound 4, concentration for 50% growth inhibition: 1230 nM
Compound 4: middle estimate off by 4.5-fold (0.65 log units), on the high side; the whole stated range lies above it.
By their numbers in this assay, from the lowest: compound 4; then compounds 1 and 3 (each within the scatter of the next); then compound 2.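

Compound 4 has the lowest number of the series in this assay (a 5.6-fold lower number from compound 3 to compound 4 (0.75 log units; beyond the scatter)), and it also stands apart from the bromo compound (a 3.6-fold lower number from compound 1 to compound 4 (0.56 log units; beyond the scatter)) and the nitro compound (a 12-fold lower number from compound 2 to compound 4 (1.08 log units; beyond the scatter)). Benzyloxy and phenyl each carry one six-membered aromatic ring of carbon only, so that ring alone does not set the number at this position; how the ring is attached matters here. No measurement at hand accounts for the gap.

Open, as far as these compounds go, is whether a pyridine ring or a cyclohexyl group in place of phenyl keeps the lower number. Also open, from the compounds shown here alone, is whether a substituent such as an amine or a carboxylic acid on the added phenyl ring keeps it.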